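Swapping methyl for chloro on compound 2

The source may hold more compounds than are shown below. What is called first, only, known or untested is meant among the compounds shown, and "the series" means these compounds.

Of the compounds shown here, two sharing a core have been measured so far: compound 1 (`CCn1cc(C(=O)O)c(=O)c2cc(F)c(N3CCN(CN4C(=O)/C(=N\NC(=S)NO)c5cc(Cl)ccc54)C(C)C3)c(F)c21`) and compound 2 (`CCn1cc(C(=O)O)c(=O)c2cc(F)c(N3CCN(CN4C(=O)/C(=N\NC(=S)NOC)c5cc(C)ccc54)C(C)C3)c(F)c21`). Among the compounds with values here, in an ADME assay on MT4 cells (Homo sapiens) for cytotoxicity, read by spectrophotometry, with a stated time of 5 days (a higher number here means that more compound is tolerated, a lower number that less compound is tolerated), compound 1 gives 209000 nM and compound 2 gives 156000 nM (the only two numbers available so far). These values lie within the usual scatter of each other, so compound 2 cannot be told apart from compound 1 on these numbers.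

The next compound to be tested is compound 3 (`CCn1cc(C(=O)O)c(=O)c2cc(F)c(N3CCN(CN4C(=O)/C(=N\NC(=S)NOC)c5cc(Cl)ccc54)C(C)C3)c(F)c21`). It has chloro in place of methyl on an aromatic carbon of compound 2 (chloro in place of methyl on an aromatic carbon). The ring carrying this swap is a six-membered aromatic ring of carbon only, part of a fused system of two rings. Within the data shown here, no measured pair differs in only one place, so the data give no direct size for this swap. Among the measured compounds shown here, with compound 1 at 209000 nM and compound 2 at 156000 nM as the only guides, no step beyond the scatter is expected in this assay. The estimated change is small (a 1.1-fold higher number from compound 2 to compound 3 (0.05 log units; within the scatter)). Compound 3 is expected at 175000 nM (estimated range 90000 nM to 320000 nM).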

Compound 3, half-maximal cytotoxic concentration: 180000 nM
Compound 3: the middle estimate sits 1.0-fold (0.01 log units) below what was measured, and the stated range covers the measured number.
By their numbers in this assay, from the lowest: compounds 2, 3 and 1 (each within the scatter of the next).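

Within the data shown here, this result gives the first two measured pairs that differ in only one place, and both show no step beyond the scatter. In this assay, putting chloro in place of methyl on this aromatic carbon, which sits meta to a fused ring and para to a fused ring, gives a number that cannot be told apart from that of the methyl compound (a 1.2-fold higher number from compound 2 to compound 3 (0.06 log units; within the scatter)), so at this position these two groups are not distinguished by this cytotoxicity read-out. The second pair concerns a different place, with methyl in place of hydrogen on an oxygen, and it too stays level (a 1.2-fold lower number from compound 1 to compound 3 (0.06 log units; within the scatter)), while nothing measured on these compounds gives a reason for either outcome.

Going by these compounds, both swaps exchange one small group for another, so it remains open whether a different kind of group on the same aromatic carbon, such as an amine or a carboxylic acid, would also leave the tolerated concentration in place. The same question stands for the oxygen, where a longer chain such as propyl in place of methyl would test how far this level result extends.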